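Alkoxy exchange at the ester of compound 3

The source may hold more compounds than are shown below. What is called first, only, known or untested is meant among the compounds shown, and "the series" means these compounds.

Measured in an ADME assay for pharmacokinetics, in simulated intestinal fluid; a higher number here means that the compound lasts longer, a lower number that the compound disappears faster:
compound 1, `CCOc1cc(NC(=O)C2(NC(=O)c3ccc4c(C5CCCC5)c(-c5ncc(Cl)cn5)n(C)c4c3)CCC2)ccc1/C=C/C(=O)N[C@@H](CCC(=O)O)C(N)=O`, gives 4.23 h.
compound 2, `CCOC(=O)/C=C/c1ccc(NC(=O)C2(NC(=O)c3ccc4c(C5CCCC5)c(-c5ncc(Cl)cn5)n(C)c4c3)CCC2)cc1OCC`, gives > 5 h, a limit of the assay and not a number.
compound 3, `CCOc1cc(NC(=O)C2(NC(=O)c3ccc4c(C5CCCC5)c(-c5ncc(Cl)cn5)n(C)c4c3)CCC2)ccc1/C=C/C(=O)OCC(C)C`, gives > 5 h, again a limit and not a number.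

Compound 3 thus stands at the upper edge of what this assay reports; (the limit of > 5 h in this assay, at which 2 of the 3 values shown sit). Compound 4, `CCOc1cc(NC(=O)C2(NC(=O)c3ccc4c(C5CCCC5)c(-c5ncc(Cl)cn5)n(C)c4c3)CCC2)ccc1/C=C/C(=O)OCC(=O)N1CCOCC1`, differs from compound 3 in one place: (morpholin-4-yl)carbonyl in place of isopropyl on a saturated chain carbon bound to an oxygen next to a carbonyl group. Among the measured compounds shown here, the one measured step at this same place is a step that the two limits leave unreadable from compound 2 to compound 3, which runs between two limits and gives no size. The steps of an at least 1.1-fold higher number from compound 1 to compound 2 (0.07 log units; that floor lies within the scatter) and an at least 1.1-fold higher number from compound 1 to compound 3 (0.07 log units; that floor lies within the scatter) concern a different place, on a carbonyl carbon, and each only reaches the limit, so neither sets a size for the alkoxy exchange either. No readable step is on hand for the change from compound 3 to compound 4, and the expectation can rest only on the limit compound 3 itself shows. Compound 4 is expected to give 4 h, within 1.5 h to 6 h. The step of an at least 1.2-fold lower number from compound 3 to compound 4 (0.09 log units; that floor lies within the scatter) is the estimated step, with a fair chance that compound 4 again returns only a limit.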

Compound 4, half-life: 3.17 h
The estimate for compound 4 lay 1.3-fold (0.10 log units) above the measured number; measured number inside the range.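

With (morpholin-4-yl)carbonyl in place of isopropyl on a saturated chain carbon bound to an oxygen next to a carbonyl group, compound 4 gives in this assay a number and not a limit, 3.17 h, the first such value among the esters shown. Against the two esters at the limit, the data give an at least 1.5-fold lower number from compound 3 to compound 4 (0.19 log units; that floor lies within the scatter) and an at least 1.5-fold lower number from compound 2 to compound 4 (0.19 log units; that floor lies within the scatter), floors that establish no change of real size. On a carbonyl carbon, ((morpholin-4-yl)carbonyl)methoxy and (1-carbamoyl-3-carboxypropyl)amino cannot be told apart, with a 1.3-fold lower number from compound 1 to compound 4 (0.13 log units; within the scatter).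

From the compounds shown here alone, the step between compound 2 and compound 3 cannot be read, as both stand at a limit, so the true size of any change at this place remains open. Also open, going by these compounds, is whether the morpholin-4-yl ring or the carbonyl sets the number, and how a dimethylamide or a carboxylic acid would read at this place.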